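This account rests on a few compounds, and the source may have more. Where it says the series, first, only, none or still open, it means among the compounds named here.

In a functional assay on cells (Homo sapiens) for antiproliferative activity, read by MTT assay, with a stated time of 48 h (on this read-out lower numbers stand for stronger inhibition and higher numbers for weaker inhibition), compound 1 (`CN(C)CCCn1c(N)c(-c2nc3ccccc3s2)c2nc(C#N)c(C#N)nc21`) gives 2930 nM. Compound 2 (`CN(C)CCn1c(N)c(-c2nc3ccccc3n2C)c2nc(C#N)c(C#N)nc21`) stands at > 50000 nM, which is a limit and not a number. Compound 3 (`CN(C)CCCn1c(N)c(-c2nc3ccccc3n2C)c2nc(C#N)c(C#N)nc21`) differs from compound 2 in its side chain: (dimethylamino)methyl in place of dimethylamino on a saturated chain carbon, two bonds along the chain from an aromatic nitrogen, (dimethylamino)methyl in place of dimethylamino, which lengthens 2-(dimethylamino)ethyl to 3-(dimethylamino)propyl. Compound 1 carries the same 3-(dimethylamino)propyl chain and gives 2930 nM, so stronger inhibition is expected, though the core differs. The expected size and direction are an at least 3.3-fold lower number from compound 2 to compound 3 (0.52 log units; beyond the scatter). For compound 3 the estimated value is 15000 nM, with an expected range of 4000 nM to 50000 nM.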

Compound 3, half-maximal inhibitory concentration: 3670 nM
Compound 3: middle estimate off by 4.1-fold (0.61 log units), on the high side; the measured number lies below the stated range.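

In this assay, 3-(dimethylamino)propyl in place of 2-(dimethylamino)ethyl gives an at least 13-fold lower number from compound 2 to compound 3 (1.13 log units; beyond the scatter), so this chain position has a large effect on this read-out. Compound 2 stands at a limit, so the full size of that step cannot be read: the limit of > 50000 nM in this assay, at which 1 of the 3 values shown sits. With the 3-(dimethylamino)propyl chain held, 1-methyl-1H-benzimidazol-2-yl in place of 1,3-benzothiazol-2-yl gives a 1.3-fold higher number from compound 1 to compound 3 (0.10 log units; within the scatter), so the two groups cannot be told apart here.

From the compounds shown here alone, it remains open whether a longer chain, such as 4-(dimethylamino)butyl, or a morpholine in place of the dimethylamino end would shift the value further. Going by these compounds, it is also open whether the 2-(dimethylamino)ethyl chain has the same effect with 1,3-benzothiazol-2-yl.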